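Swapping the aryl group on the aromatic nitrogen

This account rests on a few compounds, and the source may have more. Where it says the series, first, only, none or still open, it means among the compounds named here.

Compound 2 `CCS(=O)(=O)Nc1cc(-c2ccc3ncnc(Nc4ccc(C(=O)OC)c(OC)c4)c3c2)cnc1OC` gives 3440 nM in a functional assay on SNU-638 cells (Homo sapiens) for cytotoxicity, read by sulforhodamine B assay, with a stated time of 72 h (on this read-out lower numbers stand for stronger inhibition and higher numbers for weaker inhibition), and stands alongside compound 1 `CCS(=O)(=O)Nc1cc(-c2ccc3ncnc(Nc4ccc(OC)c(Cl)c4)c3c2)cnc1OC` with its 3620 nM; the step of a 1.1-fold lower number from compound 1 to compound 2 (0.02 log units; within the scatter) lies within the scatter. Compound 3 `CCS(=O)(=O)Nc1cc(-c2ccc3ncnc(Nc4ccc(F)nc4)c3c2)cnc1OC` is not yet measured in this assay. It differs from compound 2 by 6-fluoropyridin-3-yl in place of 3-methoxy-4-(methoxycarbonyl)phenyl on a nitrogen on an aromatic ring. Among the measured compounds shown here, the only measured step at this nitrogen, a 1.1-fold lower number from compound 1 to compound 2 (0.02 log units; within the scatter), also exchanged the aryl group and changed little, so no shift beyond the scatter is expected in either direction. Compound 3 is therefore estimated at 3500 nM, with a range from 1200 nM to 10000 nM, meaning an expected step of a 1.0-fold higher number from compound 2 to compound 3 (0.01 log units; within the scatter).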

Compound 3, half-maximal inhibitory concentration: 6520 nM
Compound 3: middle estimate off by 1.9-fold (0.27 log units), on the low side; low and high end bracket the measured number.
By their numbers in this assay, from the lowest: compounds 2, 1 and 3 (each within the scatter of the next).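

In this assay, among the compounds shown here, the 6-fluoropyridin-3-yl group brings a ring with a hetero atom to this nitrogen for the first time, after two rings of carbon only. Neither step leaves the scatter (a 1.9-fold higher number from compound 2 to compound 3 (0.28 log units; within the scatter); a 1.8-fold higher number from compound 1 to compound 3 (0.26 log units; within the scatter)), so compounds 1, 2 and 3 cannot be told apart, although the entering group has fewer heavy atoms than either group it replaces. Nothing available explains this result. Still open, going by these compounds, is whether a carboxylic acid or a basic amine on the ring would shift the number beyond the scatter. A saturated ring such as piperidine in place of the aryl group is equally untested by these compounds.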